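Nitro for bromo on the aryl thiourea terminus

The compounds below may be only part of what the source reports. "The series", "measured", "known", "first", "only" and "open" are said of these compounds alone.

Compounds measured in an assay on brain for binding affinity to adenosine receptor A1 (Rattus norvegicus), read by radioligand binding; on this read-out higher numbers stand for weaker inhibition and lower numbers for stronger inhibition:
compound 1, `CCCn1c(=O)c2nc(-c3ccc(OCC(=O)NCCN=C(S)Nc4ccc(N=C=S)cc4)cc3)[nH]c2n(CCC)c1=O`, gives 6.6 nM;
compound 2, `CCCn1c(=O)c2nc(-c3ccc(OCC(=O)NCCN=C(S)Nc4ccc(C)cc4)cc3)[nH]c2n(CCC)c1=O`, gives 16 nM;
compound 3, `CCCn1c(=O)c2nc(-c3ccc(OCC(=O)NCCN=C(S)Nc4ccc(Br)cc4)cc3)[nH]c2n(CCC)c1=O`, gives 7.26 nM.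

Compound 3 stands second highest of the three numbers in this assay. Its nearest neighbour is compound 1, a 1.1-fold higher number from compound 1 to compound 3 (0.04 log units; within the scatter), a gap within the scatter, so no order between the two can be claimed. Compound 2 is the only one that separates from it: a 2.2-fold lower number from compound 2 to compound 3 (0.34 log units; beyond the scatter).

Compound 4, `CCCn1c(=O)c2nc(-c3ccc(OCC(=O)NCCN=C(S)Nc4ccc([N+](=O)[O-])cc4)cc3)[nH]c2n(CCC)c1=O`, differs from compound 3 in one place: nitro in place of bromo on an aromatic carbon; in words, nitro in place of bromo on an aromatic carbon, para to a large group, so 4-bromophenyl becomes 4-nitrophenyl.

Two measured exchanges at this same carbon bear on the step. a 2.2-fold lower number from compound 2 to compound 3 (0.34 log units; beyond the scatter) was modest, and a 1.1-fold higher number from compound 1 to compound 3 (0.04 log units; within the scatter) stayed within the scatter. Three different groups at this position thus span only a narrow band in this assay. For the measured compounds named here, nothing among the measured compounds speaks for a nitro group specifically, so the step expected is a 1.1-fold higher number from compound 3 to compound 4 (0.04 log units; within the scatter), not clearly beyond the scatter in either direction. The estimate for compound 4 in this assay is 8 nM, with a range from 3.5 nM to 18 nM.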

Compound 4, inhibition constant: 15.9 nM
Estimate against measurement, compound 4: 2.0-fold (0.30 log units) below, within the range that was stated.
By their numbers in this assay, from the lowest: compounds 1 and 3 (each within the scatter of the next); then compounds 4 and 2 (each within the scatter of the next).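

In this assay, the aromatic carbon bearing the terminal group no longer looks indifferent to exchange: nitro separates from bromo (a 2.2-fold higher number from compound 3 to compound 4 (0.34 log units; beyond the scatter)) and from the isothiocyanate group (a 2.4-fold higher number from compound 1 to compound 4 (0.38 log units; beyond the scatter)), so the narrow band seen so far does not take in every group placed here. Nitro and methyl show no separation (a 1.0-fold lower number from compound 2 to compound 4 (0.00 log units; within the scatter)), which leaves the four compounds in two sets, compounds 1 and 3 on the lower side and compounds 2 and 4 on the higher, with the gap between the sets only modest. Heavy-atom count does not sort these sets, as nitro and the isothiocyanate group have the same count yet fall on opposite sides, and no measurement shown here accounts for the split.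

As far as these compounds go, whether the two sets hold as more groups are added remains open, since an amine, a carboxylic acid or a methoxy group at this carbon could fall in either set or outside both. Also open, from the compounds shown here alone, is whether the nitro and bromo difference carries over to the 3-substituted or 2-substituted phenyl isomers, or to a longer chain ahead of the thiourea.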